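The source may report more compounds than this note shows. Statements on the series, on what has been measured and on what is new or still open speak of the compounds shown alone.

In a physicochemical assay for lipophilicity (on this read-out higher numbers stand for higher lipophilicity and lower numbers for lower lipophilicity), compound 1 `Cn1nccc1-c1cc(C(F)(F)F)ccc1[C@H]1CCOc2cc(S(=O)(=O)Nc3nccs3)ccc21` gives 2.2 and compound 2 `Cn1nccc1-c1cc(C(F)(F)F)ccc1[C@H]1CCOc2cc(S(=O)(=O)Nc3cnccn3)ccc21` gives 1.8, which leaves compound 2 with the lower of the two numbers. Among the compounds with values here, the one measured step is a number 0.40 log units lower from compound 1 to compound 2 (beyond the scatter), and it came with pyrazin-2-yl in place of 1,3-thiazol-2-yl on a sulfonamide nitrogen. Compound 3 `Cn1nccc1-c1cc(C(F)(F)F)ccc1[C@H]1CCOc2cc(S(=O)(=O)Nc3cccnn3)ccc21` has not yet been measured. It carries pyridazin-3-yl in place of pyrazin-2-yl on that same sulfonamide nitrogen: pyridazin-3-yl in place of pyrazin-2-yl on a sulfonamide nitrogen. Within the data shown here, the measured step bears on this change only loosely, as it exchanges a different pair of groups and no measured pair shows the present exchange. Only a slight fall is therefore expected, and the estimated step is a number 0.20 log units lower from compound 2 to compound 3 (within the scatter). The expected value for compound 3 is 1.6, with an estimated range from 1.1 to 2.1.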

Compound 3, distribution coefficient: 2.2
Compound 3: the middle estimate sits 0.60 log units below what was measured; measured number above the stated range.
By their numbers in this assay, from the lowest: compound 2; then compounds 1 and 3 (each within the scatter of the next).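

On the sulfonamide nitrogen, this assay distinguishes two groups with the same atoms joined differently: pyridazin-3-yl in place of pyrazin-2-yl gives a number 0.40 log units higher from compound 2 to compound 3 (beyond the scatter) and so the arrangement of the ring atoms alone matters at this position. Set against 1,3-thiazol-2-yl, pyridazin-3-yl shows no change at the digits printed from compound 1 to compound 3 (within the scatter) and so, among the three groups on this nitrogen, pyrazin-2-yl alone stands apart, with the lowest number. Nothing shown here accounts for the difference between the two six-membered rings.

From the compounds shown here alone, whether pyrimidin-2-yl on this nitrogen would fall with pyrazin-2-yl or with pyridazin-3-yl remains open. So does the question of how far a methyl group or an amine on the pyridazin-3-yl ring would move the number.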